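The compounds below may be only part of what the source reports. "The series", "measured", "known", "first", "only" and "open" are said of these compounds alone.

Among the compounds with values here, compound 3 `CCS(=O)(=O)N1CCC[C@H](c2csc(-c3ccccc3NC(=O)c3ncc[nH]3)n2)C1` gives 0.86 in an ADME assay on microsomes from liver (Rattus norvegicus) (on this read-out lower numbers stand for lower hepatic extraction and higher numbers for higher hepatic extraction), the highest of the three numbers known here. Compound 1 `Cc1c[nH]c(C(=O)Nc2ccccc2-c2nc([C@H]3CCCN(S(C)(=O)=O)C3)cs2)n1` gives 0.71 in this assay, and compound 2 `CS(=O)(=O)N1CCC[C@H](c2csc(-c3ccccc3NC(=O)c3nc(C#N)c[nH]3)n2)C1` gives 0.67; both sit beyond the scatter below compound 3. Within the data shown here, the one step measured between compounds that differ in a single place, a number 0.040 lower from compound 1 to compound 2 (within the scatter), concerns the aromatic carbon of the shared core and stays within the scatter. Compound 4 `COC(=O)N1CCC[C@H](c2csc(-c3ccccc3NC(=O)c3ncc[nH]3)n2)C1` differs from compound 3 at another place: methoxycarbonyl in place of ethylsulfonyl on an amine nitrogen in a ring. Among the measured compounds shown here, no measured step touches the group on that amine nitrogen, so the step from compound 1 to compound 2 gives no direct guide, and the three values only show that this series has so far stayed in the upper part of the range. On that basis compound 4 is expected to come out with a small step, a number 0.080 lower from compound 3 to compound 4 (within the scatter), and an estimate of 0.78 is made for compound 4, between 0.62 and 0.92, before its measurement is known.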

Compound 4, hepatic extraction ratio: 0.69
For compound 4 the middle estimate is 0.090 above the measured one; the range from low to high includes it.
By their numbers in this assay, from the lowest: compounds 2, 4 and 1 (each within the scatter of the next); then compound 3.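

Methoxycarbonyl in place of ethylsulfonyl on an amine nitrogen in a ring gives, in this assay, a number 0.17 lower from compound 3 to compound 4 (beyond the scatter), so the group at this position can shift hepatic extraction by more than the usual scatter. Within the data shown here, the only earlier step, a number 0.040 lower from compound 1 to compound 2 (within the scatter), concerned an aromatic carbon and stayed within the scatter. Nothing shown here explains the shift at the amine nitrogen.

The compounds shown leave open whether the sulfonyl or carbonyl unit or the attached alkyl or alkoxy part matters at this position, a question that an acetyl group, a plain ethyl chain or the free amine on that nitrogen could address. From the compounds shown here alone, it also remains open whether the same exchange gives a similar step when the shared core carries methyl or cyano on its aromatic carbon.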